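Chalcone series on a benzoxaborole core: para substituent swap

The source may hold more compounds than are shown below. What is called first, only, known or untested is meant among the compounds shown, and "the series" means these compounds.

Compounds 1 to 3 share one enone-linked benzoxaborole core and differ only in the aryl group on the carbonyl carbon: compound 1 `O=C(/C=C/c1ccc2c(c1)B(O)OC2)c1cccnc1`, compound 2 `Cn1cccc1C(=O)/C=C/c1ccc2c(c1)B(O)OC2` and compound 3 `O=C(/C=C/c1ccc2c(c1)B(O)OC2)c1ccc(Cl)cc1`. In a functional assay on HCT-116 cells (Homo sapiens) for cytotoxicity, read by MTT assay, with a stated time of 48 h (a higher number here means a weaker inhibitor, a lower number a stronger inhibitor), compound 1 gives 20500 nM. Compound 2 reaches only the limit of the assay, > 100000 nM, and the limit of > 100000 nM in this assay, at which 1 of the 3 values shown sits, applies to it. Compound 3 gives 9300 nM in this assay and stands as the lowest of the two numbers shown; compound 1 sits nearest, and the step of a 2.2-fold lower number from compound 1 to compound 3 (0.34 log units; beyond the scatter) is modest. The step of an at least 4.8-fold higher number from compound 1 to compound 2 (0.68 log units; beyond the scatter) is at least modest, and the step of an at least 10-fold lower number from compound 2 to compound 3 (1.03 log units; beyond the scatter) is large.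

Compound 4 `CSc1ccc(C(=O)/C=C/c2ccc3c(c2)B(O)OC3)cc1` is not yet measured. It differs from compound 3 by methylsulfanyl in place of chloro on an aromatic carbon. Within the data shown here, none of the measured steps exchanges a substituent on the same six-membered ring of carbon only; all three replace the whole aryl group, so they bear only loosely on this change. A step within the scatter, or at most a modest one in either direction, is therefore expected for a 1.0-fold lower number from compound 3 to compound 4 (0.01 log units; within the scatter). Compound 4 is estimated at 9000 nM in this assay, within 3000 nM to 30000 nM.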

Compound 4, half-maximal inhibitory concentration: 10300 nM
For compound 4 the middle estimate is 1.1-fold (0.06 log units) below the measured one; the measured number falls inside the stated range.
By their numbers in this assay, from the lowest: compounds 3, 4 and 1 (each within the scatter of the next, the first and the last beyond it). At a limit, above all of these: compound 2.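

Methylsulfanyl in place of chloro is the first exchange in the series that keeps the six-membered aromatic ring of carbon only and alters a single substituent, on an aromatic carbon para to a large group. In this assay the change reads as a 1.1-fold higher number from compound 3 to compound 4 (0.04 log units; within the scatter), so the two groups cannot be told apart at this position, although methylsulfanyl is the larger by the heavy-atom count and carries a hydrogen-bond acceptor. No measured property on hand bears on this result.

Going by these compounds, whether the position accepts groups of a different kind, such as an amine, a carboxylic acid or a longer chain like butylsulfanyl, remains open. Also open, on these data alone, is whether a second substituent on the same ring would leave the number similarly unchanged.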